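Racemic sulfonamide against its two drawn enantiomers

The source may report more compounds than this note shows. Statements on the series, on what has been measured and on what is new or still open speak of the compounds shown alone.

Measured compounds:
compound 1, `O=S(=O)(c1ccc(Cl)cc1)N1CCC[C@@H]1c1cccs1`, with 27100 nM in an assay on cells (strain Wistar) for inhibition of Voltage-gated L-type calcium channel (Rattus norvegicus), read by patch clamp; a lower number here means a stronger inhibitor, a higher number a weaker inhibitor
compound 2, `O=S(=O)(c1ccc(Cl)cc1)N1CCC[C@H]1c1cccs1`, with 22200 nM in this assay

Compound 2 and compound 1 sit together on these numbers: a 1.2-fold lower number from compound 1 to compound 2 (0.09 log units; within the scatter). The step from compound 1 to compound 2 is the only one measured, and it bears directly on the next one, since the fact that compounds 1 and 2 differ only in the configuration as drawn means both configurations of the same stereocentre have already been read.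

Compound 3, `O=S(=O)(c1ccc(Cl)cc1)N1CCCC1c1cccs1`, is to be measured in this assay. Its change from compound 2 is the two compounds have the same atoms and bonds; at least one stereo element is drawn with a configuration in one of them and without one in the other: 1 of 1 stereo elements differ; a stereocentre at a saturated ring carbon is drawn S in compound 2 and without a configuration in compound 3. A compound drawn without configuration at that centre is expected to behave like a mixture of compound 1 and compound 2, so no step beyond the scatter is expected in either direction.

Compound 3 is therefore estimated at 24500 nM, with a range of 12000 nM to 50000 nM, which corresponds to an expected step of a 1.1-fold higher number from compound 2 to compound 3 (0.04 log units; within the scatter).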

Compound 3, half-maximal inhibitory concentration: 23500 nM
Beside the measured number, compound 3's estimate is 1.0-fold (0.02 log units) above it; the range from low to high includes it.
By their numbers in this assay, from the lowest: compounds 2, 3 and 1 (each within the scatter of the next).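

In this assay, removing the drawn configuration at the saturated ring carbon leaves the reading within the scatter of both defined forms: a 1.1-fold higher number from compound 2 to compound 3 (0.02 log units; within the scatter), and a 1.2-fold lower number from compound 1 to compound 3 (0.06 log units; within the scatter). The form without a drawn configuration therefore stands apart from neither defined form, so the flat reading seen between compound 1 and compound 2 now extends to all three drawings of this stereocentre. Each comparison isolates this one centre, as no other feature varies: the fact that one of compounds 1 and 3 is drawn with a defined configuration and the other without, at the place where they differ

All three compounds share the same atoms and bonds, so these readings say nothing about how the number responds to a change in structure rather than in configuration, such as an amine or a carboxylic acid in place of the chlorine. As far as these compounds go, whether any other channel or target tells the configurations apart also remains open.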